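A few compounds are considered here, and "the series" means these few. Any claim that something is new, unique, unknown or untested is made for them only; others in the source may bear on it.

Working notes on the series

Three compounds have so far been run in a functional assay on cells for agonist activity at Free fatty acid receptor 1 (Homo sapiens), read by FLIPR and calcium flux, with a stated time of 100 s; on this read-out higher numbers stand for an effect only at larger amounts of compound and lower numbers for an effect already at smaller amounts. Compound 1 `O=C(O)C1CC(=O)N(c2ccc(OCc3ccc(Cl)cc3Cl)cc2)C1` gives 5000 nM. Compound 2 `O=C(O)C[C@@H]1CCCN1c1ccc(OCc2ccc(Cl)cc2Cl)cc1` gives 340 nM, and compound 3 `Cc1ccccc1COc1ccc(N2CCC[C@H]2CC(=O)O)cc1` gives 190 nM. Compound 3 thus holds the lowest of the three numbers; its gap to compound 2 lies within the scatter, so no order between the two is claimed, while its gap to compound 1 lies well beyond the scatter. Within the data shown here, the only single-change step recorded among the measured compounds is a 1.8-fold lower number from compound 2 to compound 3 (0.25 log units; within the scatter), an exchange of one aromatic substituent pattern for another that leaves the number essentially unchanged.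

Compound 4 `Cc1ccccc1COc1ccc(N2CCC[C@H]2CC(=O)O)cc1C` has not yet been measured. It differs from compound 3 by methyl in place of hydrogen on an aromatic carbon. Among the measured compounds shown here, no measured step adds a methyl to an aromatic ring, so the bearing of the data is indirect: the one recorded step, already cited, shows that a change confined to an aromatic group left the number within the scatter, and a single added carbon on an aromatic ring of compound 3 is expected to behave likewise. Compound 4 is therefore estimated at 150 nM, with a range of 50 nM to 450 nM. The expected step is a 1.3-fold lower number from compound 3 to compound 4 (0.10 log units; within the scatter), not beyond the scatter.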

Compound 4, half-maximal effective concentration: > 33000 nM
Compound 4 gave a limit, no number; the forecaster's own chance of this, stated with the estimate: 5%; middle value at least 220-fold (2.34 log units) from the limit.
By their numbers in this assay, from the lowest: compounds 3 and 2 (each within the scatter of the next); then compound 1. At a limit, above all of these: compound 4.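

In this assay, methyl in place of hydrogen on an aromatic carbon, ortho to a group of 9 heavy atoms and meta to a group of 9 heavy atoms, gives an at least 170-fold higher number from compound 3 to compound 4 (2.23 log units; beyond the scatter). Among these compounds, the only earlier single-change step, a 1.8-fold lower number from compound 2 to compound 3 (0.25 log units; within the scatter), concerned the aromatic group at the far end of the chain and touched nothing on this ring, so its small size says nothing about how a change at this position reads out. Compound 4 gives a limit of the assay and not a number, so the true size of the step stays unknown and only its lower bound is fixed: the limit of > 33000 nM in this assay, at which 1 of the 4 values shown sits.

A single compound at this position leaves open whether fluorine, chlorine or a methoxy group in place of the methyl would return a measurable number, and whether a methyl on another carbon of the same ring would give the same outcome. Going by these compounds, it also remains open whether the methyl has a comparable result when the 2,4-dichlorophenyl group of compound 2 is present, and the data give no cause for the step.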